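From bromo to fluoro: one more halogen exchange

This account rests on a few compounds, and the source may have more. Where it says the series, first, only, none or still open, it means among the compounds named here.

Compound 1 `O=C1NC(=S)/C(=C/c2ccc(Cl)cc2)S1`: 22.3%
Compound 2 `O=C1NC(=S)/C(=C/c2ccc(Br)cc2)S1`: 18.2%
Compound 3 `O=C1NC(=S)/C(=C/c2ccc(F)cc2)S1`: not yet measured

In a functional assay on HEp-2 cells (Homo sapiens) for cytotoxicity, read by MTT assay, with a stated time of 72 h, tested at 10 ug/mL (a higher number here means more inhibition of growth at the concentration tested, a lower number less inhibition of growth), compound 2 gives 18.2%, which lies within the scatter of compound 1 at 22.3%. Compound 3 differs from compound 2 by fluoro in place of bromo on an aromatic carbon, in words fluoro in place of bromo on an aromatic carbon. Within the data shown here, only one measured step bears on this change: a number 4.1 percentage points lower from compound 1 to compound 2 (within the scatter), with bromo in place of chloro on an aromatic carbon. That is a single exchange of one halogen for another, and it stays within the scatter. Among the measured compounds shown here, no fluoro compound has yet been measured, so this evidence is thin, and no step beyond the scatter is expected in this assay. The estimate means a number 1.8 percentage points higher from compound 2 to compound 3 (within the scatter), which is expected to stay within the scatter. Compound 3 is expected at 20%, with an estimated range from 8% to 32%.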

Compound 3, percent growth inhibition at one concentration: 30.1%
For compound 3 the middle estimate is 10.1 percentage points below the measured one, and the stated range covers the measured number.
By their numbers in this assay, from the lowest: compounds 2, 1 and 3 (each within the scatter of the next, the first and the last beyond it).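

In this assay fluoro in place of bromo gives a number 11.9 percentage points higher from compound 2 to compound 3 (beyond the scatter) and is the only halogen exchange shown that goes beyond the scatter, so the number does respond to the halogen at this position. Fluoro in place of chloro gives only a number 7.8 percentage points higher from compound 1 to compound 3 (within the scatter) and bromo in place of chloro also stays within the scatter, so compound 1 cannot be separated from either compound 2 or compound 3, and the three halogens form no clear series. Nothing available here accounts for the difference between the fluoro and bromo compounds.

The compounds shown leave open whether a group other than a halogen, such as an amine, a methoxy group or a carboxylic acid, would change the number at this position. They also leave open whether hydrogen at this position would give a number near those of the halogens.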